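Sulfonyl substituent swap on the aryl sulfonamide arm

A few compounds are considered here, and "the series" means these few. Any claim that something is new, unique, unknown or untested is made for them only; others in the source may bear on it.

Measured so far:
compound 1, `CCOc1cccc(S(=O)(=O)Nc2ccc(N3CCN(c4cccc(-c5c(C(=O)NCCCN6CCN(C)CC6)c(C)n(C)c5-c5ccc(Cl)cc5)c4)CC3)cc2)c1`, 420 nM
compound 2, `Cc1c(C(=O)NCCCN2CCN(C)CC2)c(-c2cccc(N3CCN(c4ccc(NS(=O)(=O)c5cccc(S(=O)(=O)C(F)(F)F)c5)cc4)CC3)c2)c(-c2ccc(Cl)cc2)n1C`, 39.2 nM

Both compounds were run in an assay for binding affinity to Apoptosis regulator Bcl-2 (Homo sapiens), read by fluorescence polarization, with a stated time of 2 h; a lower number here means a stronger inhibitor, a higher number a weaker inhibitor. Compound 1 gives 420 nM. Compound 2 gives 39.2 nM and stands as the lowest of the two numbers, the nearest being compound 1. Going by the values given here, the one step measured so far is an 11-fold lower number from compound 1 to compound 2 (1.03 log units; beyond the scatter), a large move and well beyond the scatter.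

Compound 3, `Cc1c(C(=O)NCCCN2CCN(C)CC2)c(-c2cccc(N3CCN(c4ccc(NS(=O)(=O)c5cccc(S(C)(=O)=O)c5)cc4)CC3)c2)c(-c2ccc(Cl)cc2)n1C`, is not yet measured. Its change against compound 2 is methyl in place of trifluoromethyl on a sulfonyl sulfur. The same difference, cut one bond further out, reads (trifluoromethyl)sulfonyl to methylsulfonyl.

Among the compounds with values here, only the step from compound 1 to compound 2 bears on this, and it compares an ethoxy with the (trifluoromethyl)sulfonyl, not a methylsulfonyl with it. Compound 3 keeps the sulfonyl and loses the trifluoromethyl, so it is expected to sit between the two measured values, closer to compound 2. The expected step is a 2.6-fold higher number from compound 2 to compound 3 (0.41 log units; beyond the scatter), a modest rise in this assay that may stay near the scatter. Compound 3 is therefore estimated at 100 nM, with a range of 35 nM to 300 nM.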

Compound 3, inhibition constant: 658 nM
For compound 3 the middle estimate is 6.6-fold (0.82 log units) below the measured one; the measured number lies above the stated range.
By their numbers in this assay, from the lowest: compound 2; then compounds 1 and 3 (each within the scatter of the next).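

In this assay the low number of compound 2 does not carry over to every sulfonyl at this position: methyl in place of trifluoromethyl on a sulfonyl sulfur gives a 17-fold higher number from compound 2 to compound 3 (1.22 log units; beyond the scatter) and removes the whole gain that the earlier step had shown. The sulfonyl alone is therefore not enough in this set, as methylsulfonyl and ethoxy on the aromatic carbon cannot be told apart, with a 1.6-fold higher number from compound 1 to compound 3 (0.19 log units; within the scatter) as the printed step, and of the three compounds only compound 2, with its trifluoromethyl on the sulfonyl sulfur, stands apart from the others. No measurement at hand accounts for this sensitivity to the group on the sulfur.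

Still open, as far as these compounds go, is whether the low number belongs only to the (trifluoromethyl)sulfonyl as a unit, or whether a difluoromethyl or a longer chain such as ethyl on the sulfonyl sulfur would also give it. Equally open, from the compounds shown here alone, is how a trifluoromethyl or a nitrile on the aromatic carbon, with no sulfonyl at all, would compare with compound 2.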